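A few compounds are considered here, and "the series" means these few. Any claim that something is new, unique, unknown or untested is made for them only; others in the source may bear on it.

Measured compounds:
Compound 2 (`COc1ccc2[nH]c(=O)c(-c3nc4cc(Cl)ccc4[nH]3)cc2c1`), in a functional assay on SK-OV-3 cells (Homo sapiens) for cytotoxicity, read by MTT assay, with a stated time of 48 h; on this read-out higher numbers stand for weaker inhibition and lower numbers for stronger inhibition: > 100000 nM, a limit of the assay
Compound 1 (`O=c1[nH]c2ccccc2cc1-c1nc2cc([N+](=O)[O-])ccc2[nH]1`), in this assay: > 100000 nM, likewise a limit

Compound 2 stands at the limit of this assay rather than at a number. Compound 1 sits at that same limit. Both results therefore rest at the limit of > 100000 nM in this assay, at which 2 of the 2 values shown sit, and neither provides a figure from which a step could be measured. Compound 3 (`O=c1[nH]c2ccccc2cc1-c1nc2cc(Cl)ccc2[nH]1`) has not yet been measured; it differs from compound 2 by hydrogen in place of methoxy on an aromatic carbon. No measured step links any pair of these compounds, so the size of this change in this assay cannot be read from the data. Compound 3 is expected to remain at or near that limit, with an expected step of a number no higher from compound 2 to compound 3 (the limit leaves the size open), none beyond the scatter. Compound 3 is thus estimated at 100000 nM, within a range from 30000 nM to 300000 nM.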

Compound 3, half-maximal inhibitory concentration: 10500 nM
Compound 3: middle estimate off by 9.5-fold (0.98 log units), on the high side; the whole stated range lies above it.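

Compound 3 is the first of these compounds to give a number in this assay, so both changes can now be sized, though only from one side. The step of an at least 9.5-fold lower number from compound 2 to compound 3 (0.97 log units; beyond the scatter) comes with hydrogen in place of methoxy on an aromatic carbon, and the step of an at least 9.5-fold lower number from compound 1 to compound 3 (0.97 log units; beyond the scatter) comes with chloro in place of nitro on an aromatic carbon. Each size is only a minimum because compound 1 and compound 2 both stand at a limit: the limit of > 100000 nM in this assay, at which 2 of the 3 values shown sit.

The compounds shown leave open how an amine or a fluoro group in place of the chloro would read in this assay. They also leave open whether a methoxy group on another carbon of the shared core would give the same result.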